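The compounds below may be only part of what the source reports. "The series", "measured", "known", "first", "only" and "open" are said of these compounds alone.

Compound 1 `FC(F)(F)Oc1ccc(Oc2ccnc(N3CCC(NC(=S)Nc4cccnc4)CC3)c2Cl)cc1` gives 25 nM in an assay on membranes from brain for binding affinity to Lysophosphatidylserine lipase ABHD12 (Mus musculus), read by fluorescence, with a stated time of 20 min; a higher number here means a weaker inhibitor, a lower number a stronger inhibitor. Compound 2 `FC(F)(F)Oc1ccc(Oc2ccnc(N3CCC(NC(=S)Nc4cccnc4)CC3)c2Cl)c(Cl)c1`, in which (chloro in place of hydrogen on an aromatic carbon), gives 11 nM in this assay, so that the step of a 2.3-fold lower number from compound 1 to compound 2 (0.36 log units; beyond the scatter) is a modest gain. Compound 3 `FC(F)(F)c1ccnc(N2CCC(NC(=S)Nc3cccnc3)CC2)c1` is built on a different core; the difference between the two cores is not broken down here, and compound 3 gives 640 nM in this assay, the highest of the three numbers.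

Compound 4 `FC(F)(F)c1ccnc(N2CCC(NC(=S)Nc3cccnc3)CC2)c1Cl` is the compound in which (chloro in place of hydrogen on an aromatic carbon). This is the same kind of change as that from compound 1 to compound 2, but the place differs: there the carbon sat on a six-membered aromatic ring of carbon only, meta to a trifluoromethoxy group; here it sits on a six-membered aromatic ring with 1 nitrogen, ortho to a trifluoromethyl group and two atoms from the ring nitrogen. Because the earlier step of a 2.3-fold lower number from compound 1 to compound 2 (0.36 log units; beyond the scatter) was modest, compound 4 is expected to show a similar step a 2.1-fold lower number from compound 3 to compound 4 (0.33 log units; beyond the scatter) in this assay. Compound 4 is thus estimated at 300 nM in this assay, with a range from 120 nM to 800 nM.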

Compound 4, half-maximal inhibitory concentration: 300 nM
Beside the measured number, compound 4's estimate shows no gap at the digits printed, and the stated range covers the measured number.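

In this assay, chloro in place of hydrogen on an aromatic carbon gives a 2.1-fold lower number from compound 3 to compound 4 (0.33 log units; beyond the scatter), a modest step. Set beside the earlier step, the change carries over between the two cores at much the same size: the same change on two cores in this assay, a 2.3-fold lower number (0.36 log units; beyond the scatter) from compound 1 to compound 2 and a 2.1-fold lower number (0.33 log units; beyond the scatter) from compound 3 to compound 4, 1.1-fold (0.03 log units) apart, within the scatter of two such steps. For the compounds shown here, this rests on only two pairs, with the chloro on a different kind of ring in each, so it shows that the step held in these two places, but not that it would hold on other cores or at other ring positions, nor why the number falls.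

The compounds shown leave open whether a fluoro, a methyl or a methoxy group on the same carbon would give a step of like size. Also open, going by these compounds, is how an amine or a carboxylic acid there would read in this assay.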